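The source may report more compounds than this note shows. Statements on the series, on what has been measured and on what is new or still open speak of the compounds shown alone.

Working notes on the series. All compounds share the core of compound 1 `C=C(CC)C(=O)c1ccc(OCC(=O)NCCO)c(Cl)c1Cl` and differ only in the group on the amide-type nitrogen. In a functional assay on CLL cells (Homo sapiens) for cytotoxicity, read by MTT assay, with a stated time of 48 h (a lower number here means that less compound is needed, a higher number that more compound is needed for the effect), compound 1 gives only a limit, > 25000 nM, and no number. Where compound 1 stands is therefore known only through (the limit of > 25000 nM in this assay, at which 1 of the 3 values shown sits). Compound 2 `C=C(CC)C(=O)c1ccc(OCC(=O)NC2CCN(CC(=O)OC)CC2)c(Cl)c1Cl` gives 10600 nM in this assay, and compound 3 `C=C(CC)C(=O)c1ccc(OCC(=O)Nc2ccc(O)c([N+](=O)[O-])c2)c(Cl)c1Cl` gives 7400 nM. No pair of measured compounds differs in a single place, so no measured step is available and no cause for the spread can be given.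

Compound 4 `C=C(CC)C(=O)c1ccc(OCC(=O)Nc2cccc(C(=O)O)c2)c(Cl)c1Cl` has not yet been measured in this assay. It differs from compound 1 by 3-carboxyphenyl in place of 2-hydroxyethyl on an amide-type nitrogen. Compound 2 and compound 3 show that replacing the 2-hydroxyethyl group can bring the value down from the limit, though both remain weak. The step from compound 1 to compound 4 is expected to run downward, estimated as an at least 2.0-fold lower number from compound 1 to compound 4 (0.31 log units; beyond the scatter). Compound 4 is expected to give about 12000 nM in this assay, in the range 5000 nM to 30000 nM, with a real chance that only a limit is reported again.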

Compound 4, half-maximal effective concentration: 20600 nM
Compound 4: the middle estimate sits 1.7-fold (0.23 log units) below what was measured; measured number inside the range.
By their numbers in this assay, from the lowest: compounds 3, 2 and 4 (each within the scatter of the next, the first and the last beyond it). At a limit, above all of these: compound 1.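

In this assay, among these compounds, 3-carboxyphenyl in place of 2-hydroxyethyl on an amide-type nitrogen gives the first step that can be read at this position: an at least 1.2-fold lower number from compound 1 to compound 4 (0.08 log units; that floor lies within the scatter). That step is only a floor, so it shows no change beyond the scatter and does not exclude one, because the value of compound 1 is a limit and not a number: the limit of > 25000 nM in this assay, at which 1 of the 4 values shown sits. The change brings in a six-membered aromatic ring of carbon only, and at this position that exchange alone does not yield a floor that clears the scatter.

The compounds shown leave open how much of the step belongs to the ring and how much to the carboxylic acid on it. They also leave open whether an unsubstituted phenyl group, an amine or a longer chain on this nitrogen would give a lower number.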